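A few compounds are considered here, and "the series" means these few. Any claim that something is new, unique, unknown or untested is made for them only; others in the source may bear on it.

Compound 1 `OC[C@]1(c2ccc(F)cc2)NC[C@H](O)[C@H]1O`, compound 2 `COc1ccc([C@]2(CO)NC[C@@H](O)[C@@H]2O)cc1` and compound 3 `CCCCCCCCC[C@]1(CO)NC[C@@H](O)[C@@H]1O` share one core and carry different groups on the carbon that bears the hydroxymethyl arm. All three were examined in an assay on isolated protein for inhibition of alpha-mannosidase (Canavalia ensiformis), tested at 1000 uM; on this read-out higher numbers stand for more inhibition at the one concentration tested (going by the name of the read-out) and lower numbers for less inhibition. In this assay compound 1 gives 6.6%, compound 2 gives 0.2% and compound 3 gives 0%. Compound 2 therefore sits among three numbers that all lie within the usual scatter of one another, so nothing in these numbers sets it apart from compound 1 or compound 3.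

Compound 4 `OC[C@@]1(c2ccc(O)cc2)NC[C@@H](O)[C@@H]1O` has not yet been measured in this assay. It differs from compound 2 in one place: hydrogen in place of methyl on an oxygen on an aromatic ring. For the measured compounds named here, no measured pair differs in a single place, so this change has no direct precedent here. Because compound 2 gives 0.2% and its neighbours remain within the scatter of it, the step of a number 1.8 percentage points higher from compound 2 to compound 4 (within the scatter) is expected to be small, not beyond the scatter in either direction. Compound 4 is thus estimated at 2%, with a range from 0% to 12%.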

Compound 4, a percentage reported as inhibition, at one concentration (the size of the read-out at that concentration, not a potency): 2.2%
Beside the measured number, compound 4's estimate is 0.2 percentage points below it; the range from low to high includes it.
By their numbers in this assay, from the lowest: compounds 3, 2, 4 and 1 (each within the scatter of the next).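

For the compounds shown here, this is the first pair that differs in one place, and it gives a direct reading of the change from methoxy to hydroxy on an aromatic ring. In this assay, hydrogen in place of methyl on that oxygen gives a number 2 percentage points higher from compound 2 to compound 4 (within the scatter), so the two groups cannot be told apart on this read-out at the one concentration tested. Nothing available on these compounds offers an explanation for this result.

On these data alone, it remains open whether a larger group on that oxygen, such as an ethyl group or a longer chain, or an amine in place of the oxygen, would give a step beyond the scatter. As far as these compounds go, it is also open whether the same change would read alike in a compound with a clearly larger number on this read-out.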